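The source may report more compounds than this note shows. Statements on the series, on what has been measured and on what is new or still open speak of the compounds shown alone.

Three compounds that share one core and differ only in the ring on a saturated chain carbon bound to an aromatic carbon and an oxygen on a saturated carbon have been tested in a functional assay on HL-60 cells (Homo sapiens) for inhibition, read by MTT assay, with a stated time of 48 h, tested at 10 uM; on this read-out higher numbers stand for more inhibition of growth at the one concentration tested and lower numbers for less inhibition of growth. Here compound 1 (`Cc1oc2c([C@H]3CCN(C)C[C@H]3O)c(O)cc(O)c2c(=O)c1C(O)c1ccc(Cl)cc1`) gives 2%, compound 2 (`Cc1oc2c([C@H]3CCN(C)C[C@H]3O)c(O)cc(O)c2c(=O)c1C(O)c1c(Cl)cccc1Cl`) gives 14%, and compound 3 (`CCOc1ccc(Br)c(C(O)c2c(C)oc3c([C@H]4CCN(C)C[C@H]4O)c(O)cc(O)c3c2=O)c1`) gives 2%. Compound 3 thus stands level with compound 1, and only compound 2 differs from it beyond the scatter.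

Compound 4 (`Cc1oc2c([C@H]3CCN(C)C[C@H]3O)c(O)cc(O)c2c(=O)c1C(O)c1cccc(Cl)c1Cl`) makes one change to compound 3: 2,3-dichlorophenyl in place of 2-bromo-5-ethoxyphenyl on a saturated chain carbon bound to an aromatic carbon and an oxygen on a saturated carbon, with 2,3-dichlorophenyl in place of 2-bromo-5-ethoxyphenyl. Among the compounds with values here, three measured steps bear on this. Among the chlorinated rings there is a number 12 percentage points higher from compound 1 to compound 2 (beyond the scatter), and the swap to 2-bromo-5-ethoxyphenyl gives a number 12 percentage points lower from compound 2 to compound 3 (beyond the scatter) but also no change at the digits printed from compound 1 to compound 3 (within the scatter). Compound 4 is a dichlorophenyl like compound 2, but its chlorines sit differently, so only part of that modest gap is likely to return. A small rise in this assay is therefore expected. The expected change is a number 6 percentage points higher from compound 3 to compound 4 (within the scatter). For compound 4 the estimated value is 8%, with an expected range from 0% to 20%.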

Compound 4, percent growth inhibition at one concentration: 12%
Beside the measured number, compound 4's estimate is 4 percentage points below it; low and high end bracket the measured number.
By their numbers in this assay, from the lowest: compounds 1, 3, 4 and 2 (each within the scatter of the next, the first and the last beyond it).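

In this assay, 2,3-dichlorophenyl in place of 2,6-dichlorophenyl gives a number 2 percentage points lower from compound 2 to compound 4 (within the scatter) and so does not separate these two dichlorophenyl rings. The other two rings cannot be separated from 2,3-dichlorophenyl either, with a number 10 percentage points higher from compound 3 to compound 4 (within the scatter) and a number 10 percentage points higher from compound 1 to compound 4 (within the scatter) at this place, even though compound 2 stands beyond the scatter from both compound 1 and compound 3. Nothing measured here on these compounds explains how any of these rings acts on growth inhibition.

Every ring shown is a phenyl ring carrying halogen, so how a plain phenyl ring, or a phenyl ring carrying an amine or a carboxylic acid, would read at this place remains open. Also open, as far as these compounds go, is whether these rings would differ more clearly at other concentrations, as only one was tested.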